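Swapping trifluoromethyl for methoxy in a cytotoxicity series

The source may report more compounds than this note shows. Statements on the series, on what has been measured and on what is new or still open speak of the compounds shown alone.

Measured so far in a functional assay on PC-12 cells (Rattus norvegicus) for cytotoxicity, read by MTT assay, with stated times of 2 h and 24 h, tested at 1 uM; on this read-out lower numbers stand for a weaker effect and higher numbers for a stronger effect at the one concentration tested:
compound 1, `Oc1cc(C(F)(F)F)ccc1-c1nc(-c2ccccc2O)n(-c2ccccc2C(F)(F)F)n1`, gives 71%
compound 2, `COc1ccccc1-n1nc(-c2ccc(C(F)(F)F)cc2O)nc1-c1ccccc1O`, gives 70.7%
compound 3, `Oc1cc(C(F)(F)F)ccc1-c1nc(-c2ccccc2O)n(-c2cccc(C(F)(F)F)c2)n1`, gives 71.5%

All three share a core carrying two hydroxyphenyl groups; they differ only in the aryl group attached to the ring nitrogen. Compound 1 and compound 3 are built from the same atoms joined differently: 3-(trifluoromethyl)phenyl in place of 2-(trifluoromethyl)phenyl on an aromatic nitrogen. In this assay this rearrangement gives a number 0.5 percentage points higher from compound 1 to compound 3 (within the scatter), so the two cannot be told apart here.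

Compound 1 and compound 2 differ by methoxy in place of trifluoromethyl on an aromatic carbon. The step is a number 0.3 percentage points lower from compound 1 to compound 2 (within the scatter), again within the scatter.

Compound 4, `COc1cccc(-n2nc(-c3ccc(C(F)(F)F)cc3O)nc2-c2ccccc2O)c1`, is not yet measured. It relates to compound 3 the way compound 2 relates to compound 1: methoxy in place of trifluoromethyl on an aromatic carbon. The change is the same kind of change, but not the same, since in compound 2 the new methoxy sits ortho to a large group, while in compound 4 it sits meta to a large group. Because the earlier exchange produced a number 0.3 percentage points lower from compound 1 to compound 2 (within the scatter), and because moving the trifluoromethyl between these two positions produced a number 0.5 percentage points higher from compound 1 to compound 3 (within the scatter), the expected step for compound 4 is a number 0.5 percentage points lower from compound 3 to compound 4 (within the scatter). Compound 4 is therefore expected to give about 71% in this assay, with a likely range from 63% to 79%, resting on the three measured compounds sitting within the scatter of one another.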

Compound 4, a percentage reported as activity, at one concentration (the size of the read-out at that concentration, not a potency): 68.3%
Beside the measured number, compound 4's estimate is 2.7 percentage points above it; the measured number falls inside the stated range.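

In this assay, methoxy in place of trifluoromethyl gives a number 3.2 percentage points lower from compound 3 to compound 4 (within the scatter), and the two comparisons that change the aryl group on the ring nitrogen, a number 2.4 percentage points lower from compound 2 to compound 4 (within the scatter) and a number 2.7 percentage points lower from compound 1 to compound 4 (within the scatter), also stay inside the usual spread of repeated measurements. Set side by side, the exchange of trifluoromethyl for methoxy cannot be told apart between the two cores: the same change on two cores in this assay, a number 0.3 percentage points lower (within the scatter) from compound 1 to compound 2 and a number 3.2 percentage points lower (within the scatter) from compound 3 to compound 4, 2.9 percentage points apart, within the scatter of two such steps. This shows that no dependence on the core can be detected in this read-out at the one concentration tested, but it does not show that the change carries over identically, as a modest difference between cores could lie hidden within the scatter, and neither step shows that the exchange itself has any effect.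

The aryl groups shown are only 2-(trifluoromethyl)phenyl, 3-(trifluoromethyl)phenyl, 2-methoxyphenyl and 3-methoxyphenyl, which leaves open how the read-out would respond to a different kind of group on that ring, such as an amine or a carboxylic acid. Also open, from the compounds shown here alone, is whether these four compounds would separate from one another at concentrations other than the one tested.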